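The source may hold more compounds than are shown below. What is called first, only, known or untested is meant among the compounds shown, and "the series" means these compounds.

Compound 1 `CCC/C=C/C(=O)Nc1cccc(Oc2nc(Nc3cccc(OC)c3)nc3c2CSCC3)c1`: 33800 nM
Compound 2 `CC/C=C/C(=O)Nc1cccc(Oc2nc(Nc3ccc(OC)cc3)nc3c2CSCC3)c1`: 27200 nM

Only these two compounds have been measured so far in a functional assay on HeLa cells (Homo sapiens) for antiproliferative activity, read by MTT assay, with a stated time of 72 h; a higher number here means a weaker inhibitor, a lower number a stronger inhibitor. In this assay, compound 2 gives 27200 nM and stands level with compound 1 at 33800 nM, the two numbers lying within the scatter of each other. The next compound to be tested is compound 3 `CCC/C=C/C(=O)Nc1cccc(Oc2nc(Nc3ccc(OC)cc3)nc3c2CSCC3)c1`. It departs from compound 2 by methyl in place of hydrogen on a saturated chain carbon, two bonds along the chain from a double-bonded chain carbon, so that but-1-en-1-yl becomes pent-1-en-1-yl.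

Among the measured compounds shown here, no step between measured compounds that differ in one place is available, so the data offer no direct measure of what this change does. For the measured compounds named here, the only guide is the narrow spread of the two numbers in hand. No shift beyond the scatter is therefore expected in this assay, in either direction. The expected step of a 1.0-fold higher number from compound 2 to compound 3 (0.01 log units; within the scatter) stays small. For compound 3 the estimated value is 28000 nM, with an expected range from 13000 nM to 58000 nM.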

Compound 3, half-maximal inhibitory concentration: 12800 nM
Compound 3: middle estimate off by 2.2-fold (0.34 log units), on the high side, outside the stated range (below it).
By their numbers in this assay, from the lowest: compound 3; then compounds 2 and 1 (each within the scatter of the next).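

In this assay, but-1-en-1-yl becoming pent-1-en-1-yl gives a 2.1-fold lower number from compound 2 to compound 3 (0.33 log units; beyond the scatter). The saturated chain carbon two bonds along the chain from a double-bonded chain carbon therefore responds to the addition of a single methyl, something the two earlier compounds, which differ in two places, could not show. With the pent-1-en-1-yl chain held constant, 4-methoxyphenyl in place of 3-methoxyphenyl on the nitrogen gives a 2.6-fold lower number from compound 1 to compound 3 (0.42 log units; beyond the scatter), so the aryl group on that nitrogen also affects the number, and both steps are modest. Nothing in the available data accounts for either step.

The compounds shown leave open whether a longer chain, such as hex-1-en-1-yl, or a branched chain would extend the step seen with the added methyl, and whether an amine at the end of the chain would be tolerated. They also leave open whether the chain step would recur with 3-methoxyphenyl on the nitrogen, and whether a fluorine or a hydroxyl in place of the methoxy group would change the number in this assay at all.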